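Formyl in place of nitro: notes on weak inhibitors

The source may hold more compounds than are shown below. What is called first, only, known or untested is meant among the compounds shown, and "the series" means these compounds.

Compound 1 (`COc1cc(C(=O)/C=C/c2cccc(O)c2)cc(OC)c1OC`): 94000 nM
Compound 2 (`COc1cc(C(=O)/C=C/c2ccc([N+](=O)[O-])cc2)cc(OC)c1OC`): > 100000 nM

For the measured compounds named here, both compounds were read in a functional assay on HepG2 cells (Homo sapiens) for inhibition, read by MTT assay, with a stated time of 48 h (on this read-out higher numbers stand for weaker inhibition and lower numbers for stronger inhibition), where compound 1 gives 94000 nM and is the only true number so far.

Compound 2 reads > 100000 nM, which is a limit and not a number: the limit of > 100000 nM in this assay, at which 1 of the 2 values shown sits.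

The next compound, compound 3 (`COc1cc(C(=O)/C=C/c2ccc(C=O)cc2)cc(OC)c1OC`), has formyl in place of nitro on an aromatic carbon, para to a large group: formyl in place of nitro on an aromatic carbon.

With compound 1 at 94000 nM as the only reference, weak inhibition is expected again. A small move toward stronger inhibition is expected in this assay, and the estimated size is an at least 1.4-fold lower number from compound 2 to compound 3 (0.15 log units; that floor lies within the scatter).

Compound 3 is estimated at 70000 nM, with an expected range from 25000 nM to 100000 nM.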

Compound 3, half-maximal inhibitory concentration: > 100000 nM
Compound 3 ended at the assay's limit; the forecaster's own chance of this, stated with the estimate: 40%; at least 1.4-fold (0.15 log units) between middle value and limit.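

In this assay compound 3 gives > 100000 nM, which is a limit and not a number, so the change to formyl from nitro on an aromatic carbon, para to a large group, cannot be read. For the compounds shown here, the swap of 3-hydroxyphenyl for 4-formylphenyl gives an at least 1.0-fold higher number from compound 1 to compound 3 (0.02 log units; that floor lies within the scatter); this is only a floor, so it establishes no real separation from the single true number. Neither of the two groups tested at this position gives a readable value, and the set now sits mostly at one ceiling: the limit of > 100000 nM in this assay, at which 2 of the 3 values shown sit.

Going by these compounds, how far compound 2 and compound 3 lie beyond that limit remains open. Also open, on these data alone, is whether an amine or a carboxylic acid on the same aromatic carbon would give a readable value.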